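A few compounds are considered here, and "the series" means these few. Any claim that something is new, unique, unknown or untested is made for them only; others in the source may bear on it.

Measured in an ADME assay on microsomes from liver (Homo sapiens) for metabolic stability; a lower number here means slower removal, a higher number faster removal of the compound:
- Compound 1 `CCn1cnc2c(-c3ccc(F)c(-c4ccc(C#N)cc4OC)c3)cnnc21`: 32 mL.min-1.g-1
- Compound 2 `CCn1cnc2c(-c3ccc(F)c(-c4cc(C(=O)NC)ccc4F)c3)cnnc21`: 34 mL.min-1.g-1
- Compound 3 `CCn1cnc2c(-c3ccc(F)c(-c4ccc(S(C)(=O)=O)cc4OC)c3)cnnc21`: < 8 mL.min-1.g-1

The value of compound 3 is a limit of the assay and not a number. It is the limit of < 8 mL.min-1.g-1 in this assay, at which 1 of the 3 values shown sits, so the true position of compound 3 in this assay is not known more closely.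

The next compound, compound 4 `CCn1cnc2c(-c3ccc(F)c(-c4ccc(S(=O)(=O)C(C)C)cc4OC)c3)cnnc21`, has isopropyl in place of methyl on a sulfonyl sulfur. The rest of the structure stays the same.

For the measured compounds named here, one measured step bears on this change. It runs an at least 4.0-fold lower number from compound 1 to compound 3 (0.60 log units; beyond the scatter), with methylsulfonyl in place of cyano on an aromatic carbon, and it lies beyond the scatter. That step brings the sulfonyl group in but does not vary what sits on the sulfur, so it gives a setting and not a size. Going by the values given here, no measured pair makes the change from methyl to isopropyl. A small rise in this assay is therefore expected, as a cautious judgement from the added carbon count alone, and a result at the same limit would be no surprise.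

The expected change is estimated as an at least 1.3-fold higher number from compound 3 to compound 4 (0.13 log units; that floor lies within the scatter).

For compound 4 the estimate is 11 mL.min-1.g-1, with an expected range of 7 mL.min-1.g-1 to 22 mL.min-1.g-1.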

Compound 4, intrinsic clearance in microsomes in the Homo sapiens assay: 84 mL.min-1.g-1
Compound 4: middle estimate off by 7.6-fold (0.88 log units), on the low side; the whole stated range lies below it.
By their numbers in the Homo sapiens assay, from the lowest: compounds 1 and 2 (each within the scatter of the next); then compound 4. At a limit, below all of these: compound 3.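

In the Homo sapiens assay, isopropyl in place of methyl on the sulfonyl sulfur gives an at least 10-fold higher number from compound 3 to compound 4 (1.02 log units; beyond the scatter), so the number at this position depends strongly on what the sulfur carries and not on the presence of the sulfonyl group alone. In the same assay, compound 3 gives < 8 mL.min-1.g-1, which is a limit of the assay and not a number. The lower number seen with methylsulfonyl in place of cyano does not carry over to isopropylsulfonyl, which gives a 2.6-fold higher number from compound 1 to compound 4 (0.42 log units; beyond the scatter). In a physicochemical assay for lipophilicity (on this read-out lower numbers stand for lower lipophilicity and higher numbers for higher lipophilicity), compound 3 gives 2.5 and compound 4 gives 3, and a single pair cannot settle whether this difference is the cause of the faster removal on going from methyl to isopropyl: the measured distribution coefficient of compound 3, 2.5, and of compound 4, 3, a number 0.50 log units higher (beyond the scatter)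

With only methyl and isopropyl shown on the sulfur, it remains open whether the number climbs steadily with the size of the chain or turns on the isopropyl group itself, and ethyl, cyclopropyl or an amine at that place would help to separate these readings. From the compounds shown here alone, it also remains open how far below its limit compound 3 truly lies, and so how large the full step to isopropyl is.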